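Vero Cell Cytotoxicity: From Compound 1 to Compound 3

This account rests on a few compounds, and the source may have more. Where it says the series, first, only, none or still open, it means among the compounds named here.

Compound 1 `CN(Cc1ccc2c(c1)OCCO2)c1nc(=O)c2cc(C(F)(F)F)cc([N+](=O)[O-])c2o1`: 9.27 ug/mL
Compound 2 `O=c1nc(NCc2ccc3c(c2)OCCO3)oc2c([N+](=O)[O-])cc(C(F)(F)F)cc12`: 25.3 ug/mL

In an ADME assay on Vero cells (Chlorocebus sabaeus) for cytotoxicity, read by MTT assay, with a stated time of 48 h (a higher number here means a weaker inhibitor, a lower number a stronger inhibitor), compound 1 gives 9.27 ug/mL, the lower of the two numbers shown; its nearest neighbour is compound 2 with 25.3 ug/mL, and the step of a 2.7-fold higher number from compound 1 to compound 2 (0.44 log units; beyond the scatter) concerns hydrogen in place of methyl on a nitrogen on an aromatic ring. Compound 3 `COc1ccc(CN(C)c2nc(=O)c3cc(C(F)(F)F)cc([N+](=O)[O-])c3o2)cc1OC` differs from compound 1 at another place: 3,4-dimethoxyphenyl in place of 2,3-dihydro-1,4-benzodioxin-6-yl on a saturated chain carbon bound to a nitrogen on an aromatic ring. Among the compounds with values here, no measured step touches that position, so the single known step gives no guide to direction. For compound 3 the expected step is a 1.1-fold higher number from compound 1 to compound 3 (0.03 log units; within the scatter), none beyond the scatter. Compound 3 is therefore estimated at 10 ug/mL in this assay, within 5 ug/mL to 20 ug/mL.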

Compound 3, half-maximal inhibitory concentration: 9.46 ug/mL
Compound 3: the middle estimate sits 1.1-fold (0.02 log units) above what was measured; measured number inside the range.
By their numbers in this assay, from the lowest: compounds 1 and 3 (each within the scatter of the next); then compound 2.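

In this assay, 3,4-dimethoxyphenyl in place of 2,3-dihydro-1,4-benzodioxin-6-yl on a saturated chain carbon gives a 1.0-fold higher number from compound 1 to compound 3 (0.01 log units; within the scatter) and so no difference that can be read. At this place, then, the non-aromatic ring of compound 1 can give way to two separate methoxy groups with the number staying within the scatter. Nothing measured here bears on why the two groups read alike. From the compounds shown here alone, whether a plain phenyl or a pyridine ring would read the same at this place remains open. So does whether 3,4-dimethoxyphenyl would match 2,3-dihydro-1,4-benzodioxin-6-yl with hydrogen on the nitrogen, as in compound 2.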